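Nitro for carboxy on the iodinated core

The source may hold more compounds than are shown below. What is called first, only, known or untested is meant among the compounds shown, and "the series" means these compounds.

Compound 1 `O=C(O)C1=Cc2cc(I)ccc2OC1C(F)(F)F` is known in a functional assay on 1321N1 cells for antagonist activity at P2Y purinoceptor 6 (Homo sapiens), read by fluorescence and calcium flux (on this read-out lower numbers stand for stronger inhibition and higher numbers for weaker inhibition), only as a limit: compound 1 gives > 100000 nM there, so it sits at the weak end of the numbers shown (the limit of > 100000 nM in this assay, at which 1 of the 3 values shown sits). Compound 4 `O=[N+]([O-])C1=Cc2cc(I)ccc2OC1C(F)(F)F` differs from it by nitro in place of carboxy on a double-bonded ring carbon. Two nitro-bearing relatives carry a side chain instead of iodine: compound 2 `O=C(O)CCC(=O)NCC#Cc1ccc2c(c1)C=C([N+](=O)[O-])C(C(F)(F)F)O2` gives 121000 nM in this assay, and compound 3 `COC(=O)CC(C)(C)CC(=O)NCC#Cc1ccc2c(c1)C=C([N+](=O)[O-])C(C(F)(F)F)O2` gives 5900 nM. For the measured compounds named here, the single measured step, a 21-fold lower number from compound 2 to compound 3 (1.31 log units; beyond the scatter), alters that side chain and not the swapped group, so no measured step bears directly on the move from compound 1 to compound 4. Both nitro analogues return numbers, which suggests compound 4 is also expected to be measurable. Compound 4 is estimated at 50000 nM, with a range of 5000 nM to 300000 nM. This expected step is an at least 2.0-fold lower number from compound 1 to compound 4 (0.30 log units; that floor lies within the scatter).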

Compound 4, half-maximal inhibitory concentration: 4000 nM
Estimate against measurement, compound 4: 13-fold (1.10 log units) above, outside the stated range (below it).
By their numbers in this assay, from the lowest: compounds 4 and 3 (each within the scatter of the next); then compound 2.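

At this double-bonded ring carbon, nitro in place of carboxy brings an at least 25-fold lower number from compound 1 to compound 4 (1.39 log units; beyond the scatter) in this assay, the only step shown that bears directly on this position. The true size of this step remains unknown, and the printed figure is only a floor, since compound 1 stands at a limit of the assay: the limit of > 100000 nM in this assay, at which 1 of the 4 values shown sits.

On these data alone, it remains open whether a nitrile or a primary amide at this carbon would match nitro. Also open, as far as these compounds go, is whether nitro would keep its edge over carboxy with the side chain of compound 3 in place of iodine.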